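The source may report more compounds than this note shows. Statements on the series, on what has been measured and on what is new or still open speak of the compounds shown alone.

The series shares one core, carried by compound 1 `Cc1ccc(CN(C)C(=O)c2nn(-c3ccc(F)cc3)c(OC[C@@H](O)C[C@@H](O)CC(=O)O)c2C(C)C)cc1`, compound 2 `Cc1ccccc1CNC(=O)c1nn(-c2ccc(F)cc2)c(OC[C@@H](O)C[C@@H](O)CC(=O)O)c1C(C)C` and compound 3 `COc1ccccc1CNC(=O)c1nn(-c2ccc(F)cc2)c(OC[C@@H](O)C[C@@H](O)CC(=O)O)c1C(C)C`. In a functional assay on L6 cells (Rattus norvegicus) for inhibition (a lower number here means a stronger inhibitor, a higher number a weaker inhibitor), compound 1 gives 1250 nM, and compound 2 gives 2850 nM; for compound 3 the result in this assay is "not determined" (no result reported). Within the data shown here, on the numbers at hand compound 1 stands lowest of the two, with compound 2 as its nearest neighbour: the step of a 2.3-fold higher number from compound 1 to compound 2 (0.36 log units; beyond the scatter) is the only measured step in the set, and it alters the amide substituent on the carbonyl carbon.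

Compound 4 `CC(C)c1c(C(=O)N(C)Cc2ccc(F)cc2)nn(-c2ccc(F)cc2)c1OC[C@@H](O)C[C@@H](O)CC(=O)O` is the next entry. Relative to compound 1 the change is fluoro in place of methyl on an aromatic carbon. Among the measured compounds shown here, no measured pair in the set exchanges one small group for another on that aromatic carbon; the one step available, from compound 1 to compound 2, concerns a different part of the molecule and bears on compound 4 only loosely, as a sign that small alterations in the amide region have so far given modest shifts. Nothing here points to a shift beyond the scatter in this assay, in either direction. The step of a 1.0-fold higher number from compound 1 to compound 4 (0.02 log units; within the scatter) is expected to stay inside the usual scatter. Compound 4 is estimated at 1300 nM in this assay, with a range from 500 nM to 3500 nM.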

Compound 4, half-maximal inhibitory concentration: 2800 nM
Compound 4: the middle estimate sits 2.2-fold (0.33 log units) below what was measured; measured number inside the range.
By their numbers in this assay, from the lowest: compound 1; then compounds 4 and 2 (each within the scatter of the next).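

Notes on the aromatic position: in this assay this is the first reading of a change at the aromatic carbon para to a large group, with the rest of the molecule held constant. Going from 4-methylbenzyl to 4-fluorobenzyl gives a 2.2-fold higher number from compound 1 to compound 4 (0.35 log units; beyond the scatter), so this position is not silent, although the shift is modest and the exchange is limited to methyl and fluoro. The step of a 1.0-fold lower number from compound 2 to compound 4 (0.01 log units; within the scatter) lies within the scatter, which leaves compound 1 with the lowest number of the three measured compounds, and nothing measured here accounts for the shift from methyl to fluoro.

Open, from the compounds shown here alone, is whether methyl is specifically favoured at this carbon, or whether chloro, methoxy, trifluoromethyl or plain hydrogen there would read like methyl, like fluoro or like neither. Also open, going by these compounds, is how much the methyl on the amide nitrogen contributes separately from the benzyl substitution, a question that a (4-methylbenzyl)amino amide on the same core would address, since the step from compound 1 to compound 2 changes both at once.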